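Swapping an Anilinoamino Group for a Methylpiperazine Ring

This account rests on a few compounds, and the source may have more. Where it says the series, first, only, none or still open, it means among the compounds named here.

Compound 2 `O=C(Nc1sc2c(c1C(=O)NNc1ccccc1)CCCCC2)NS(=O)(=O)c1ccccc1` gives 15200 nM in a functional assay on OVCAR-3 cells (Homo sapiens) for inhibition, with a stated time of 48 h; on this read-out higher numbers stand for weaker inhibition of growth and lower numbers for stronger inhibition of growth. Going by the values given here, it holds the only actual number in this set; the other compound reached only a limit. Compound 1 `NNC(=O)c1c(NC(=O)NS(=O)(=O)c2ccccc2)sc2c1CCCCC2` sits at the assay limit of > 100000 nM in this assay. That limit is recorded as the limit of > 100000 nM in this assay, at which 1 of the 2 values shown sits, and is not a measured value. Going from compound 1 to compound 2, which is the addition of a phenyl on an amine nitrogen, gives an at least 6.5-fold lower number from compound 1 to compound 2 (0.81 log units; beyond the scatter).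

Compound 3 `CN1CCN(C(=O)c2c(NC(=O)NS(=O)(=O)c3ccccc3)sc3c2CCCCC3)CC1` differs from compound 2 by 4-methylpiperazin-1-yl in place of anilinoamino on a carbonyl carbon. Among the compounds with values here, no measured step covers this exact exchange. Within the data shown here, the one measured step, an at least 6.5-fold lower number from compound 1 to compound 2 (0.81 log units; beyond the scatter), shows that the phenyl-bearing anilinoamino group is what lifted compound 2 above the limit; compound 3 removes that phenyl along with both hydrogen-bond donors and brings in a 4-methylpiperazin-1-yl ring instead. The expected outcome is therefore a move back toward weaker inhibition, with the step from compound 2 to compound 3 estimated at a 3.9-fold higher number from compound 2 to compound 3 (0.60 log units; beyond the scatter). Compound 3 is expected to give about 60000 nM in this assay, within a range from 15000 nM to 200000 nM, with a real chance that only a limit is reported.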

Compound 3, concentration for 50% growth inhibition: > 100000 nM
Compound 3 gave a limit, no number; the forecaster's own chance of this, stated with the estimate: 45%; middle value at least 1.6-fold (0.22 log units) away from the limit.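

The swap from anilinoamino to 4-methylpiperazin-1-yl on the carbonyl carbon gives an at least 6.5-fold higher number from compound 2 to compound 3 (0.81 log units; beyond the scatter) in this assay, so the growth inhibition seen with compound 2 does not survive this change. Compound 1 had already shown that removing the phenyl costs activity, and compound 3 adds that a six-membered non-aromatic ring with 2 hetero atoms at the same place does not restore a measurable number, so simply having a ring on this carbonyl carbon is not enough in these compounds. The step between compound 1 and compound 3 cannot be read, as both stand at a limit rather than a number: the limit of > 100000 nM in this assay, at which 2 of the 3 values shown sit.

The exchange removes the aromatic ring and the hydrogen-bond donors together, and the compounds shown cannot tell which of these changes matters, or whether both do. A 4-phenylpiperazin-1-yl group on the same carbonyl carbon would keep an aromatic ring with no hydrogen on the attached nitrogen, while a cyclohexylamino group would keep a donor with no aromatic ring, and neither group is among these compounds.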